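The source may report more compounds than this note shows. Statements on the series, on what has been measured and on what is new or still open speak of the compounds shown alone.

Among the compounds with values here, in a physicochemical assay, read by spectrophotometry, with a stated time of 30 min (on this read-out higher numbers stand for weaker inhibition and lower numbers for stronger inhibition), compound 1 `COc1cc(/C=N/NC(=O)CCCc2nc3ccccc3c(=O)[nH]2)ccc1O` gives 236000000 nM and compound 2 `O=C(CCCc1nc2ccccc2c(=O)[nH]1)N/N=C/c1ccc([N+](=O)[O-])cc1` gives 316000000 nM so the only two measured compounds stand level, within the scatter. Compound 2 therefore has just one neighbour on these numbers, and no trend can yet be read from them. The next change leads to compound 3 `O=C(CCCc1nc2ccccc2c(=O)[nH]1)N/N=C/c1ccc(Cl)cc1` and puts chloro in place of nitro on an aromatic carbon, para to a large group (chloro in place of nitro on an aromatic carbon). Within the data shown here, only one measured step bears on this position, the exchange of 4-hydroxy-3-methoxyphenyl for 4-nitrophenyl, which gave a 1.3-fold higher number from compound 1 to compound 2 (0.13 log units; within the scatter) and so moved the number no further than repeat measurements would. A single step is thin evidence, but it gives no ground to expect a real shift in this assay from this smaller exchange. The estimated change is a 1.1-fold lower number from compound 2 to compound 3 (0.05 log units; within the scatter) and so none beyond the scatter is expected. Compound 3 is estimated at 280000000 nM (expected range 120000000 nM to 650000000 nM).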

Compound 3, half-maximal inhibitory concentration: 353000000 nM
Compound 3: the middle estimate sits 1.3-fold (0.10 log units) below what was measured; the range from low to high includes it.
By their numbers in this assay, from the lowest: compounds 1, 2 and 3 (each within the scatter of the next).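

In this assay, chloro in place of nitro on this aromatic carbon swaps three heavy atoms for one and gives a 1.1-fold higher number from compound 2 to compound 3 (0.05 log units; within the scatter) and so adds a second exchange on this ring that stays inside the scatter. The wider change from 4-hydroxy-3-methoxyphenyl to 4-chlorophenyl gives a 1.5-fold higher number from compound 1 to compound 3 (0.17 log units; within the scatter) and shows that the three groups on the carbon with a double bond to nitrogen stand level here, even at the widest gap among them. Nothing shown accounts for this lack of separation, so its reason stays unknown.

On these data alone, all three compounds share the same core and chain, so the effect of an amine or a carboxylic acid on this aromatic carbon remains open. Also open, as far as these compounds go, is whether a longer chain would move the number beyond the scatter.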